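This account rests on a few compounds, and the source may have more. Where it says the series, first, only, none or still open, it means among the compounds named here.

Measured so far:
compound 1 `Nc1ccccc1-c1ncc(C(=O)O)c(=O)[nH]1`: 50 mg/kg
compound 2 `O=C(O)c1cnc(-c2ccccc2O)[nH]c1=O`: > 5 mg/kg
compound 3 `CCCOc1ccccc1-c1ncc(C(=O)O)c(=O)[nH]1`: 0.9 mg/kg

All three share one core and differ only in the group on the carbon ring. The value of compound 2 is a limit of the assay, not a number. Compound 2 sits at the limit of > 5 mg/kg in this assay, at which 1 of the 3 values shown sits, and its place among the three cannot be fixed more closely.

Compound 4 `C[S+]([O-])c1ccccc1-c1ncc(C(=O)O)c(=O)[nH]1` is not yet measured. Its change from compound 2: a group of 3 heavy atoms (1 carbon, 1 oxygen, 1 sulfur; no ring) in place of one oxygen atom, on an aromatic carbon.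

Within the data shown here, two measured steps bear on this. One is a step that the limit leaves unreadable from compound 1 to compound 2. The other is an at least 5.5-fold lower number from compound 2 to compound 3 (0.74 log units; beyond the scatter), where the hydroxy hydrogen was replaced by propyl. Compound 4 also loses the hydroxy hydrogen, so a lower dose than the limit of compound 2 is expected, with wide uncertainty. The expected step is an at least 1.2-fold lower number from compound 2 to compound 4 (0.09 log units; that floor lies within the scatter). Compound 4 is estimated at 4 mg/kg, between 1 mg/kg and 20 mg/kg.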

Compound 4, dose for 50% inhibition: > 5 mg/kg
Compound 4: only a limit was reported; the forecaster's own chance of this, stated with the estimate: 35%; middle value at least 1.2-fold (0.09 log units) from the limit.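

In a functional assay on the whole organism (strain Sprague-Dawley) for inhibition, with Rattus norvegicus as the target, with a stated time of 10 min (on this read-out lower numbers stand for an effect already at smaller amounts and higher numbers for an effect only at larger amounts of compound), compound 4 reaches only a limit of the assay, not a number, and it is the same limit as for compound 2: the limit of > 5 mg/kg in this assay, at which 2 of the 4 values shown sit. Losing the hydroxy hydrogen is therefore not enough on its own to give a low dose on this aromatic carbon, as the propoxy group separates clearly from the group in compound 4, with an at least 5.5-fold higher number from compound 3 to compound 4 (0.74 log units; beyond the scatter). The steps to compound 4 from compound 1 and from compound 2 cannot be read.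

As far as these compounds go, what stays open is how the dose changes with the chain on that oxygen, as with methoxy or butoxy. From the compounds shown here alone, it is also open whether a propyl chain on sulfur would behave like propoxy.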